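Hydrazone Analogues on Liver Cells: Predicting a Dibrominated Phenol

A few compounds are considered here, and "the series" means these few. Any claim that something is new, unique, unknown or untested is made for them only; others in the source may bear on it.

Measured in a functional assay on HepG2 cells (Homo sapiens) for cytotoxicity, read by MTT assay, with a stated time of 48 h; a lower number here means a stronger inhibitor, a higher number a weaker inhibitor:
Compound 1, `O=C(CSc1nnc(-c2ccncc2)o1)N/N=C/c1ccc([N+](=O)[O-])cc1`, gives 17900 nM.
Compound 2, `O=C(CSc1nnc(-c2ccncc2)o1)N/N=C/c1ccc(O)cc1`, gives 5510 nM.
Compound 3, `O=C(CSc1nnc(-c2ccncc2)o1)N/N=C/c1ccccc1F`, gives 16000 nM.

The three compounds share one core and differ only in the aryl group on the carbon with a double bond to nitrogen. Compound 3 has the second highest number of the three. Its gap to compound 1 is small: a 1.1-fold lower number from compound 1 to compound 3 (0.05 log units; within the scatter). Its gap to compound 2 is larger: a 2.9-fold higher number from compound 2 to compound 3 (0.46 log units; beyond the scatter).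

The next compound, compound 4, is `O=C(CSc1nnc(-c2ccncc2)o1)N/N=C/c1cc(Br)cc(Br)c1O`. The change from compound 3 is 3,5-dibromo-2-hydroxyphenyl in place of 2-fluorophenyl on a carbon with a double bond to nitrogen. Among the measured compounds shown here, of the measured steps, only the one that also swaps in a hydroxy-bearing ring bears on this: a 2.9-fold higher number from compound 2 to compound 3 (0.46 log units; beyond the scatter), a modest step in this assay. For the measured compounds named here, the two bromine atoms have no counterpart among the measured compounds, so their effect cannot be read from the data. On that basis the number for compound 4 is expected to come out somewhat lower than for compound 3, roughly a 2.3-fold lower number from compound 3 to compound 4 (0.36 log units; beyond the scatter). The estimate for compound 4 in this assay is 7000 nM, with a range from 2500 nM to 20000 nM.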

Compound 4, half-maximal inhibitory concentration: 6540 nM
Compound 4: middle estimate off by 1.1-fold (0.03 log units), on the high side; the range from low to high includes it.
By their numbers in this assay, from the lowest: compounds 2 and 4 (each within the scatter of the next); then compounds 3 and 1 (each within the scatter of the next).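

In this assay, the aryl group on the carbon with a double bond to nitrogen now gives a second case of a hydroxy-bearing ring on the low side: a 2.4-fold lower number from compound 3 to compound 4 (0.39 log units; beyond the scatter) and a 2.7-fold lower number from compound 1 to compound 4 (0.44 log units; beyond the scatter), while the step between the two hydroxy-bearing rings is small, a 1.2-fold higher number from compound 2 to compound 4 (0.07 log units; within the scatter). Among these four compounds, both rings with a hydroxy group give lower numbers than both rings without one, and no compound goes against this, so the link between hydroxy and a lower number no longer rests on a single compound, and the larger 3,5-dibromo-2-hydroxyphenyl group still fits that pattern. Nothing available here explains why these rings differ in this way.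

Going by these compounds, the 2-hydroxy and 3,5-dibromo parts of the new group enter together, so the share of each in this step stays unknown; a plain 2-hydroxyphenyl ring and a 3,5-dibromophenyl ring would pull them apart. On these data alone, it also remains open whether hydroxy itself matters on this ring, which a 4-aminophenyl or 4-methoxyphenyl group in its place could test.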